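The source may hold more compounds than are shown below. What is called first, only, known or untested is meant among the compounds shown, and "the series" means these compounds.

Measured so far in an ADME assay on Huh-5-2 cells (Homo sapiens) for cytotoxicity, read by WST assay, with a stated time of 3 days; a higher number here means that more compound is tolerated, a lower number that less compound is tolerated:
- compound 1, `O=c1c(OCc2ccccc2Br)c(-c2ccccc2)oc2cc(O)cc(O)c12`: 12000 nM
- compound 2, `O=c1c(OCc2ccccc2[N+](=O)[O-])c(-c2ccccc2)oc2cc(O)cc(O)c12`: 51000 nM
- compound 3, `COc1ccccc1COc1c(-c2ccccc2)oc2cc(O)cc(O)c2c1=O`: 53000 nM

On the numbers shown, compound 3 and compound 2 sit together: the step of a 1.0-fold higher number from compound 2 to compound 3 (0.02 log units; within the scatter) is within the scatter, so the two cannot be ordered. Both stand apart from compound 1, which gives the lowest number of the three: the steps of a 4.3-fold higher number from compound 1 to compound 2 (0.63 log units; beyond the scatter) and a 4.4-fold higher number from compound 1 to compound 3 (0.65 log units; beyond the scatter) are modest but beyond the scatter.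

Compound 4, `N#Cc1cccc(COc2c(-c3ccccc3)oc3cc(O)cc(O)c3c2=O)c1`, is the next member. Its difference from compound 3 is 3-cyanophenyl in place of 2-methoxyphenyl on a saturated chain carbon bound to an oxygen on an aromatic ring. For the measured compounds named here, no measured step changes the substituent on the benzyl ring in this way; the steps that bear on it are the three above, all of which alter only that substituent. Two of them are modest and one is within the scatter, so a change on the benzyl ring moves this assay little. The expectation is therefore a step from compound 3 to compound 4 of no more than modest size, direction uncertain, most likely within the scatter; the estimated step is a 1.3-fold lower number from compound 3 to compound 4 (0.12 log units; within the scatter).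

Compound 4 is thus estimated at 40000 nM, within a range of 15000 nM to 100000 nM.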

Compound 4, half-maximal cytotoxic concentration: 21000 nM
Beside the measured number, compound 4's estimate is 1.9-fold (0.28 log units) above it; measured number inside the range.
By their numbers in this assay, from the lowest: compounds 1 and 4 (each within the scatter of the next); then compounds 2 and 3 (each within the scatter of the next).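

In this assay, the 3-cyanobenzyl group gives a 2.5-fold lower number from compound 3 to compound 4 (0.40 log units; beyond the scatter) and a 2.4-fold lower number from compound 2 to compound 4 (0.39 log units; beyond the scatter), whereas a 1.8-fold higher number from compound 1 to compound 4 (0.24 log units; within the scatter) leaves compound 4 and compound 1 unordered. Among the earlier compounds, only the 2-bromobenzyl group stood apart from the 2-nitrobenzyl and 2-methoxybenzyl groups; the series now falls into two sets, compound 1 with compound 4 and compound 2 with compound 3, so the lower set is no longer represented by the bromo compound alone. No measurement shown here offers an explanation for this grouping.

The step to 3-cyanophenyl changes both the group and the ring position it occupies, so the compounds shown cannot separate the contribution of the nitrile from that of its placement, as they include neither 2-cyanobenzyl nor a 3-methoxybenzyl, 3-nitrobenzyl or 3-bromobenzyl partner. Also open, as far as these compounds go, is where this assay would place compounds carrying an amine or a carboxylic acid on the benzyl ring, or a phenethyl group in place of the benzyl group.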